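Notes on replacing 4-fluorophenyl with isopentyl

The source may hold more compounds than are shown below. What is called first, only, known or untested is meant among the compounds shown, and "the series" means these compounds.

In a physicochemical assay for acid dissociation, compound 1 (`COc1ccc(F)cc1CNCCCNc1ccnc2cc(C3CCCCC3)ccc12`) gives 9.47, compound 2 (`Fc1ccc(-c2ccc3c(NCCCNCc4ccco4)ccnc3c2)cc1`) gives 9.47 and compound 3 (`COc1cccc(CNCCCNc2ccnc3cc(-c4ccc(F)cc4)ccc23)c1O`) gives 9.47, so compound 2 stands level with both others. Compound 4 (`CC(C)CCc1ccc2c(NCCCNCc3ccco3)ccnc2c1`) has isopentyl in place of 4-fluorophenyl on an aromatic carbon. Going by the values given here, the only measured step, no change at the digits printed from compound 2 to compound 3 (within the scatter), lies elsewhere, on a saturated chain carbon bound to an amine nitrogen, so it bears on this change only indirectly. Compound 1 also lacks 4-fluorophenyl and differs from compound 2 in more than one place, yet compound 1 reads 9.47. No step beyond the scatter is therefore expected, and the estimated step is no change at the digits printed from compound 2 to compound 4 (within the scatter). For compound 4 the expected value is 9.47, with an estimated range of 9.2 to 9.75.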

Compound 4, acid dissociation constant: 9.47
The estimate for compound 4 equals the measured number at the digits printed, within the range that was stated.
By their numbers in this assay, from the lowest: compounds 1, 2, 3 and 4 (each within the scatter of the next).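

In this assay, the swap of 4-fluorophenyl for isopentyl on this aromatic carbon reads no change at the digits printed from compound 2 to compound 4 (within the scatter). Going by these compounds alone, this is the first single-place step at this position, as the earlier step lay on a saturated chain carbon bound to an amine nitrogen, and it shows that the read-out does not separate the aromatic ring from the ringless isopentyl here. Nothing available explains this reading. Still open, on these data alone, is whether a group carrying an amine or a carboxylic acid at this aromatic carbon would read level with compound 2.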